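The source may hold more compounds than are shown below. What is called first, only, known or untested is meant among the compounds shown, and "the series" means these compounds.

Measured compounds in this series:

Compound 1, `COc1cc2c(Oc3ccc(NC(=O)c4nn(-c5ccc([N+](=O)[O-])cc5)c(=O)c5ccccc45)cc3F)ccnc2cc1OCCCN1CCCC1`: 2980 nM
Compound 2, `COc1ccc(-n2nc(C(=O)Nc3ccc(Oc4ccnc5cc(OCCCN6CCCC6)c(OC)cc45)c(F)c3)c3ccccc3c2=O)cc1`: 3450 nM
Compound 3, `COc1cc2c(Oc3ccc(NC(=O)c4nn(-c5ccc([N+](=O)[O-])cc5)c(=O)c5ccccc45)cc3F)ccnc2cc1OCCCN1CCCCC1`: 2620 nM

All three were read in a functional assay on MDA-MB-231 cells (Homo sapiens) for cytotoxicity, read by MTT assay, with a stated time of 72 h; on this read-out higher numbers stand for weaker inhibition and lower numbers for stronger inhibition. Compound 1 and compound 3 share one core apart from piperidin-1-yl in place of pyrrolidin-1-yl on a saturated chain carbon, three bonds along the chain from an oxygen on an aromatic ring; that change gave a 1.1-fold lower number from compound 1 to compound 3 (0.06 log units; within the scatter). Compound 2 differs from compound 1 by methoxy in place of nitro on an aromatic carbon, which gave a 1.2-fold higher number from compound 1 to compound 2 (0.06 log units; within the scatter). Compound 3 and compound 2 differ in two places at once, and their two values in this assay lie within the scatter of each other.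

Compound 4, `COc1ccc(-n2nc(C(=O)Nc3ccc(Oc4ccnc5cc(OCCCN6CCCCC6)c(OC)cc45)c(F)c3)c3ccccc3c2=O)cc1`, has not yet been measured in this assay. It differs from compound 3 by methoxy in place of nitro on an aromatic carbon, the same change as from compound 1 to compound 2, made on the core of compound 3 rather than the core of compound 1; the surroundings of the place are the same in both cases.

For compound 4 a step of a 1.1-fold higher number from compound 3 to compound 4 (0.06 log units; within the scatter) is expected, beside the measured 1.2-fold higher number from compound 1 to compound 2 (0.06 log units; within the scatter), because a 1.1-fold lower number from compound 1 to compound 3 (0.06 log units; within the scatter) shows that the core change itself hardly moved the number. Among the measured compounds shown here, compound 4 is therefore estimated at 3000 nM, with a range of 1500 nM to 6000 nM, resting on only one measured instance of this change.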

Compound 4, half-maximal inhibitory concentration: 2010 nM
Beside the measured number, compound 4's estimate is 1.5-fold (0.17 log units) above it; measured number inside the range.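

In this assay, methoxy in place of nitro gives a 1.3-fold lower number from compound 3 to compound 4 (0.12 log units; within the scatter) on the core of compound 3, and this step agrees with the earlier one on the core of compound 1: the same change on two cores in this assay, a 1.2-fold higher number (0.06 log units; within the scatter) from compound 1 to compound 2 and a 1.3-fold lower number (0.12 log units; within the scatter) from compound 3 to compound 4, 1.5-fold (0.18 log units) apart, within the scatter of two such steps

With methoxy present, piperidin-1-yl in place of pyrrolidin-1-yl gives a 1.7-fold lower number from compound 2 to compound 4 (0.23 log units; within the scatter) and this step also agrees with its earlier counterpart: the same change on two cores in this assay, a 1.1-fold lower number (0.06 log units; within the scatter) from compound 1 to compound 3 and a 1.7-fold lower number (0.23 log units; within the scatter) from compound 2 to compound 4, 1.5-fold (0.18 log units) apart, within the scatter of two such steps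

Among the compounds shown here, both changes therefore carry from one core to the other without a difference beyond the scatter, but all four steps are themselves within the scatter, so the series shows only that neither change moved the number measurably here, and it does not show how a step large enough to read would transfer, with each comparison resting on just two instances.

The compounds shown leave open whether an amine or a nitrile in place of the nitro or methoxy group would give a step beyond the scatter. Also open, on these data alone, is whether a morpholine ring in place of the pyrrolidine or piperidine ring, or a longer chain carrying it, would do so.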